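The source may report more compounds than this note shows. Statements on the series, on what has been measured and on what is new or still open speak of the compounds shown alone.

Measured in a functional assay on HCT-116 cells (Homo sapiens) for antiproliferative activity, read by MTT assay, with a stated time of 48 h; a higher number here means a weaker inhibitor, a lower number a stronger inhibitor:
- compound 1 `CCCCCCCCCCC(CCO)n1cnc2c(N(C)C)ncnc21`: 5490 nM
- compound 2 `CCCCCCCCCCCC(CCO)n1cnc2c(NC)ncnc21`: 15400 nM

Only these two numbers are available, and compound 2 holds the higher of them. Against compound 2 (15400 nM), compound 1 (5490 nM) reads lower, a gap beyond the usual scatter of the measurement.

The next compound, compound 3 `CCCCCCCCCCCC(CCO)n1cnc2c(N(C)C)ncnc21`, is reached from compound 2 by a single change: methyl in place of hydrogen on a nitrogen on an aromatic ring. This places methyl in place of hydrogen on a nitrogen on an aromatic ring, turning methylamino into dimethylamino. Among the measured compounds shown here, no measured pair shows this change on its own, so the size of the step cannot be read directly. For the measured compounds named here, the only guide is that compound 1, which also carries dimethylamino, gives the lower number (5490 nM), although it is not a strict partner for compound 3. A moderate move towards stronger inhibition is therefore expected, while a result within the scatter would not be surprising. The estimated step is a 2.4-fold lower number from compound 2 to compound 3 (0.37 log units; beyond the scatter). For compound 3 the expected value is 6500 nM, with an estimated range of 2800 nM to 15000 nM.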

Compound 3, half-maximal inhibitory concentration: 12000 nM
Compound 3: middle estimate off by 1.8-fold (0.27 log units), on the low side; the measured number falls inside the stated range.
By their numbers in this assay, from the lowest: compound 1; then compounds 3 and 2 (each within the scatter of the next).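

In this assay the change from methylamino to dimethylamino can now be read on its own: a 1.3-fold lower number from compound 2 to compound 3 (0.11 log units; within the scatter) lies within the scatter, so on this chain the methyl in place of hydrogen on the nitrogen gives no difference that can be told from repeat measurement. With dimethylamino held constant, the chain gives the clearer result, since methyl in place of hydrogen on a saturated chain carbon gives a 2.2-fold higher number from compound 1 to compound 3 (0.34 log units; beyond the scatter) as a modest step beyond the scatter. No available measurement offers an explanation for either step.

Going by these compounds, each change rests on a single pair, so it remains open whether methylamino and dimethylamino would also match on the chain of compound 1, or whether the chain step would hold with methylamino in place. The compounds shown also leave open how a still longer chain, a primary amine on the shared core, or a carboxylic acid in place of the hydroxyl group would read in this assay.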